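A few compounds are considered here, and "the series" means these few. Any claim that something is new, unique, unknown or untested is made for them only; others in the source may bear on it.

Compound 2 `O=C(Nn1c(-c2cccc([N+](=O)[O-])c2)nc2c(-c3cccs3)n[nH]c2c1=O)c1cccnc1` gives 10.2% in a functional assay on A549 cells (Homo sapiens) for cytotoxicity, read by sulforhodamine B assay, with a stated time of 2 days, tested at 100 uM (a lower number here means less inhibition, a higher number more inhibition at the concentration tested (going by the name of the read-out)), the lower of the two numbers recorded so far. For the measured compounds named here, its nearest neighbour, compound 1 `O=C(Nn1c(-c2cccc([N+](=O)[O-])c2)nc2c(-c3ccc(F)cc3)n[nH]c2c1=O)c1cccnc1`, gives 28.8% in this assay; the single measured step, a number 18.6 percentage points lower from compound 1 to compound 2 (beyond the scatter), came from thiophen-2-yl in place of 4-fluorophenyl on an aromatic carbon, and shows that exchanging the group at that place moves the read-out by a modest amount rather than a large one. Compound 3 `O=C(Nn1c(-c2cccc([N+](=O)[O-])c2)nc2c(CCc3ccccc3)n[nH]c2c1=O)c1cccnc1` differs from compound 2 by phenethyl in place of thiophen-2-yl on an aromatic carbon. Going by the values given here, no measured step covers phenethyl, so the earlier step bears on the present one only in its size, not in its direction: the data do not say whether a phenethyl group raises or lowers inhibition relative to thiophen-2-yl. The step of a number 9.8 percentage points higher from compound 2 to compound 3 (within the scatter) is therefore expected to be modest at most, possibly within the scatter, with a slight lean upward since compound 2 sits at the bottom of the two values. The estimate for compound 3 is 20%, within a range from 5% to 40%.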

Compound 3, a percentage reported as inhibition, at one concentration (the size of the read-out at that concentration, not a potency): 19%
Estimate against measurement, compound 3: 1 percentage points above; the range from low to high includes it.
By their numbers in this assay, from the lowest: compounds 2, 3 and 1 (each within the scatter of the next, the first and the last beyond it).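

In this assay, the place on the aromatic carbon of the five-membered aromatic ring now carries phenethyl, the first group shown there that holds its ring on a chain, and the read-out stays in the range already set by the two groups before it. For the compounds shown here, the new steps, a number 8.8 percentage points higher from compound 2 to compound 3 (within the scatter) and a number 9.8 percentage points lower from compound 1 to compound 3 (within the scatter), both lie within the scatter, so phenethyl cannot be told apart from either thiophen-2-yl or 4-fluorophenyl, even though those two groups are separated by a number 18.6 percentage points lower from compound 1 to compound 2 (beyond the scatter); the only difference beyond the scatter at this place therefore remains the one between the two groups without a chain. No measured information on the compounds accounts for any of these numbers.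

On these data alone, whether a shorter or longer chain than phenethyl, or a chain ending in an amine or a carboxylic acid, would move the read-out beyond the scatter of all three compounds stays open. The compounds shown also share the rest of the core and a single tested concentration, so they leave open how other groups on that core behave and how potent any of these compounds is.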